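One smaller group on a sulfonyl sulfur

The compounds below may be only part of what the source reports. "The series", "measured", "known", "first", "only" and "open" are said of these compounds alone.

Compound 1 `CCn1c([C@@H](C)NS(=O)(=O)C2CC2)nc2ccc(C(F)(F)F)cc21`: < 3 mL.min-1.g-1
Compound 2 `CCn1c([C@@H](C)NS(=O)(=O)c2ccc(C#N)cc2)nc2ccc(C(F)(F)F)cc21`: 34 mL.min-1.g-1
Compound 3 `CCCn1cc(S(=O)(=O)N[C@H](C)c2nc3ccc(C(F)(F)F)cc3n2CC)c(C)n1`: > 100 mL.min-1.g-1

In an ADME assay (liver) for metabolic stability, with Liver microsome (Homo sapiens) as the target, read by LC-MS, using microsomes and NADPH, with a stated time of 5 min, at 37 degrees C (a lower number here means slower removal, a higher number faster removal of the compound), compound 3 gives > 100 mL.min-1.g-1, which is a limit of the assay. Compound 1 gives < 3 mL.min-1.g-1, also a limit. Compound 4 `CCn1ncc(S(=O)(=O)N[C@H](C)c2nc3ccc(C(F)(F)F)cc3n2CC)c1C` changes only the group on the sulfonyl sulfur: a group of 8 heavy atoms (6 carbon, 2 nitrogen; one five-membered aromatic ring with 2 hetero atoms) in place of a group of 9 heavy atoms (7 carbon, 2 nitrogen; one five-membered aromatic ring with 2 hetero atoms), on a sulfonyl sulfur. Three measured steps at this place bear on it: an at least 11-fold higher number from compound 1 to compound 2 (1.05 log units; beyond the scatter), an at least 33-fold higher number from compound 1 to compound 3 (1.52 log units; beyond the scatter) and an at least 2.9-fold higher number from compound 2 to compound 3 (0.46 log units; beyond the scatter). All lie beyond the scatter, and among these three compounds the number rises with the size of the group. The group of compound 4 matches that of compound 2 in heavy-atom count, and compound 2 gives 34 mL.min-1.g-1. A modest fall is therefore expected, with an estimated at least 2.0-fold lower number from compound 3 to compound 4 (0.30 log units; that floor lies within the scatter). Compound 4 is estimated at 50 mL.min-1.g-1, with an expected range of 20 mL.min-1.g-1 to 110 mL.min-1.g-1.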

Compound 4, intrinsic clearance in microsomes: > 100 mL.min-1.g-1
Compound 4 ended at the assay's limit; the forecaster's own chance of this, stated with the estimate: 20%; at least 2.0-fold (0.30 log units) between middle value and limit.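

In this assay, placing 1-ethyl-5-methyl-1H-pyrazol-4-yl on the sulfonyl sulfur gives an at least 2.9-fold higher number from compound 2 to compound 4 (0.46 log units; beyond the scatter) and an at least 33-fold higher number from compound 1 to compound 4 (1.52 log units; beyond the scatter). Compound 2 and compound 4 carry groups of equal heavy-atom count, so they go against the earlier rise with group size, and heavy-atom count alone does not order these groups. The step from compound 3 to compound 4 cannot be read because both compounds sit at the same limit: the limit of > 100 mL.min-1.g-1 in this assay, at which 2 of the 4 values shown sit.

Any real difference between the propyl-bearing and ethyl-bearing rings stays open. Also open, from the compounds shown here alone, is whether an amine or a carboxylic acid on the five-membered ring would bring the number down from that limit.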